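A few compounds are considered here, and "the series" means these few. Any claim that something is new, unique, unknown or untested is made for them only; others in the source may bear on it.

Compound 1, `CCCn1cc2c(Nc3ccc(OC(F)(F)F)cc3)ncnc2n1`: in an ADME assay on BaF3 cells (Mus musculus) for cytotoxicity (a higher number here means that more compound is needed for the effect, a lower number that less compound is needed), compound 1 gives > 10000 nM, which is a limit of the assay rather than a number.
Compound 2, `NC(=O)Cn1ncc2c(Nc3ccc(OC(F)(F)F)cc3)ncnc21`: in this assay compound 2 gives 3300 nM.

Compound 1 thus sits at the edge of what the assay resolves (the limit of > 10000 nM in this assay, at which 1 of the 2 values shown sits); only a limit is known for it. Compound 3, `FC(F)(F)Oc1ccc(Nc2ncnc3nn(Cc4ccccc4)cc23)cc1`, is not yet measured. It differs from compound 1 by phenyl in place of ethyl on a saturated chain carbon bound to an aromatic nitrogen. Going by the values given here, no measured pair shows this change, so no step beyond the scatter is expected; the expected step is a number no higher from compound 1 to compound 3 (the limit leaves the size open). Compound 3 is estimated at 10000 nM, with a range from 3000 nM to 30000 nM, and may again return only a limit.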

Compound 3, half-maximal effective concentration: > 10000 nM
Compound 3: a limit, no number; the forecaster's own chance of this, stated with the estimate: 55%; the middle value lies on the limit itself.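

In this assay compound 3 gives > 10000 nM, a limit of the assay and not a number. Going by these compounds alone, compound 1 also stands at a limit, so no step between compound 1 and compound 3 can be read. The compounds shown leave open what phenyl in place of ethyl does to the value.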